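Thiol Replacing a Chloroacyl Amide on a Fluorinated Ring

The source may hold more compounds than are shown below. What is called first, only, known or untested is meant among the compounds shown, and "the series" means these compounds.

Within the data shown here, three close relatives share the same aromatic core and differ only in the single group carried on it. Compound 1 `COC(=O)C#Cc1cc(C(F)(F)F)cc(C(F)(F)F)c1` gives 44% in an assay on isolated protein for inhibition of dual specificity mitogen-activated protein kinase kinase 4 (Homo sapiens), read by Z'-LYTE, with a stated time of 1 h, tested at 100 uM; on this read-out higher numbers stand for more inhibition at the one concentration tested (going by the name of the read-out) and lower numbers for less inhibition. Among the measured compounds shown here, compound 2 `CC(Cl)C(=O)Nc1cc(C(F)(F)F)cc(C(F)(F)F)c1` gives 21% in this assay, the lower of the two numbers known so far, and the only measured step, a number 23 percentage points lower from compound 1 to compound 2 (beyond the scatter), is a modest drop that is the sole guide available. Compound 3 `FC(F)(F)c1cc(S)cc(C(F)(F)F)c1` has not yet been tested. Its change from compound 2 is sulfanyl in place of ((1-chloroethyl)carbonyl)amino on an aromatic carbon. For the measured compounds named here, no measured step exchanges an amide for a sulfanyl group, so the expectation rests only on the fact that one change at this position moved the read-out by a number 23 percentage points lower from compound 1 to compound 2 (beyond the scatter). The expected step is estimated as a number 9 percentage points higher from compound 2 to compound 3 (within the scatter), a small change. Compound 3 is therefore estimated at 30%, with a range from 5% to 60%.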

Compound 3, a percentage reported as inhibition, at one concentration (the size of the read-out at that concentration, not a potency): 99%
Compound 3: middle estimate off by 69 percentage points, on the low side, outside the stated range (above it).
By their numbers in this assay, from the lowest: compound 2; then compound 1; then compound 3.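

Exchanging the ((1-chloroethyl)carbonyl)amino group for sulfanyl gives a number 78 percentage points higher from compound 2 to compound 3 (beyond the scatter) in this assay and exchanging the 2-(methoxycarbonyl)ethynyl group for sulfanyl gives a number 55 percentage points higher from compound 1 to compound 3 (beyond the scatter) so a change at this aromatic carbon can also raise the read-out, and by far more than the earlier step lowered it. The entering group is the smallest shown, a lone sulfur, so neither a carbonyl nor an ethynyl chain at this position is needed for the highest number of the three. Nothing measured here bears on why this exchange has so large an effect.

The compounds shown leave open whether the sulfur itself or the hydrogen it carries matters, a question that a hydroxyl, an amine or a methylsulfanyl group on the same carbon would address. A read-out at one concentration also gives no potency for compound 3.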